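Aminopyridyl in place of pyridyl: expected liver microsome clearance

A few compounds are considered here, and "the series" means these few. Any claim that something is new, unique, unknown or untested is made for them only; others in the source may bear on it.

Compound 1 `Cc1cc(C)c(-c2c[nH]nc2C)cc1NC(=O)c1ccc(OCc2ccccn2)cc1` and compound 2 `Cc1cc(C)c(-c2cccnc2)cc1NC(=O)c1ccc(OCc2ccccn2)cc1` share one core and differ only in the ring attached to it. In an ADME assay on microsomes from liver (Rattus norvegicus) for metabolic stability (on this read-out lower numbers stand for slow clearance and higher numbers for fast clearance), compound 1 gives 55 mL.min-1.g-1. In this assay compound 2 gives 78 mL.min-1.g-1. Going by the values given here, the step of a 1.4-fold higher number from compound 1 to compound 2 (0.15 log units; within the scatter) is within the scatter, so the two numbers cannot be told apart; compound 2 therefore stands level with the only other compound measured, and no ordering between them is justified.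

Compound 3 `Cc1cc(C)c(-c2cccc(N)n2)cc1NC(=O)c1ccc(OCc2ccccn2)cc1` is the next member. The change from compound 2 is 6-aminopyridin-2-yl in place of pyridin-3-yl on an aromatic carbon. Among the compounds with values here, the only measured step that touches this position, a 1.4-fold higher number from compound 1 to compound 2 (0.15 log units; within the scatter), exchanged one aromatic ring for another and stayed within the scatter. On that basis the step from compound 2 to compound 3 is also expected to stay within the scatter, with no clear direction; the expected step is a 1.1-fold lower number from compound 2 to compound 3 (0.05 log units; within the scatter). Compound 3 is therefore estimated to give about 70 mL.min-1.g-1 in this assay, with a range from 35 mL.min-1.g-1 to 140 mL.min-1.g-1.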

Compound 3, intrinsic clearance in microsomes: 155 mL.min-1.g-1
Beside the measured number, compound 3's estimate is 2.2-fold (0.35 log units) below it, outside the stated range (above it).
By their numbers in this assay, from the lowest: compounds 1, 2 and 3 (each within the scatter of the next, the first and the last beyond it).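

In this assay, the exchange of pyridin-3-yl for 6-aminopyridin-2-yl gives a 2.0-fold higher number from compound 2 to compound 3 (0.30 log units; within the scatter), so this pair still cannot be told apart, even though the step reaches the edge of the usual scatter. The other comparison at this position is clearer: 6-aminopyridin-2-yl in place of 3-methyl-1H-pyrazol-4-yl gives a 2.8-fold higher number from compound 1 to compound 3 (0.45 log units; beyond the scatter), a modest step and the first one here that lies beyond the scatter. This shows that the choice of ring on this aromatic carbon can shift microsomal clearance in this series, which the earlier pair could not show, but no measurement at hand explains the shift.

The change from compound 2 to compound 3 alters two things at once, the place where the ring is attached and the presence of an amine, and the compounds shown do not separate these two parts. A pyridin-2-yl ring carrying no amine, or a pyridin-3-yl ring carrying an amine, would show how much each part contributes on its own.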